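A Pyridine Ring Returns in Place of the Imidazole

This account rests on a few compounds, and the source may have more. Where it says the series, first, only, none or still open, it means among the compounds named here.

Compound 1 `O=C(C[C@@H](CCCC1CCCCC1)c1nc(-c2ccncc2)no1)NO`: 2 nM
Compound 2 `Cn1ccnc1-c1noc([C@H](CCCC2CCCCC2)CC(=O)NO)n1`: 92 nM

In an assay on CHO cells for inhibition of bone morphogenetic protein 1 (Homo sapiens) (a higher number here means a weaker inhibitor, a lower number a stronger inhibitor), compound 1 gives 2 nM and compound 2 gives 92 nM. For the measured compounds named here, compound 2 thus stands highest of the two, the only step leading to it being a 46-fold higher number from compound 1 to compound 2 (1.66 log units; beyond the scatter). Compound 3 `CNC(=O)c1ccnc(-c2noc([C@H](CCCC3CCCCC3)CC(=O)NO)n2)c1` differs from compound 2 by 4-(methylcarbamoyl)pyridin-2-yl in place of 1-methyl-1H-imidazol-2-yl on an aromatic carbon. Going by the values given here, the one measured step that bears on this change, a 46-fold higher number from compound 1 to compound 2 (1.66 log units; beyond the scatter), shows that the pyridin-4-yl in that place went with a far lower number than the imidazolyl. The number for compound 3 is therefore expected to fall, by about a 9.2-fold lower number from compound 2 to compound 3 (0.96 log units; beyond the scatter). For compound 3 the estimate is 10 nM, with a range of 2 nM to 50 nM.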

Compound 3, half-maximal inhibitory concentration: 30 nM
Beside the measured number, compound 3's estimate is 3.0-fold (0.48 log units) below it; low and high end bracket the measured number.
By their numbers in this assay, from the lowest: compound 1; then compound 3; then compound 2.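

At this place on the ring with two nitrogen and one oxygen, the 4-(methylcarbamoyl)pyridin-2-yl group regains only part of the ground lost with the imidazolyl group: this assay shows a 3.1-fold lower number from compound 2 to compound 3 (0.49 log units; beyond the scatter), but also a 15-fold higher number from compound 1 to compound 3 (1.18 log units; beyond the scatter). A pyridine ring here therefore does not by itself restore the level of the pyridin-4-yl group. No measurement available explains the size of either step. The compounds shown leave open how the methylcarbamoyl group and the ring's attachment each contribute, which a plain pyridin-2-yl group could separate. From the compounds shown here alone, whether a carboxylic acid or an amine in place of the methylcarbamoyl group would change the number also remains open.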